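Methyl to Fluoro on the Outer Ring: Compound 3

A few compounds are considered here, and "the series" means these few. Any claim that something is new, unique, unknown or untested is made for them only; others in the source may bear on it.

Compound 2 `Cc1ccc(-n2cc(-c3ccc(/C=C4\C(=O)Nc5ccc(F)cc54)cc3)nn2)cc1` is one of two compounds tested in a functional assay on HT-29 cells (Homo sapiens) for inhibition, read by CCK-8 assay, with a stated time of 24 h; a higher number here means a weaker inhibitor, a lower number a stronger inhibitor; compound 2 gives 3980 nM, the lower of the two numbers, and compound 1 `Cc1cccc(-n2cc(-c3ccc(/C=C4\C(=O)Nc5ccc(F)cc54)cc3)nn2)c1` gives 7320 nM, so the pair sits within the scatter a 1.8-fold lower number from compound 1 to compound 2 (0.26 log units; within the scatter). Compound 3 `O=C1Nc2ccc(F)cc2/C1=C/c1ccc(-c2cn(-c3ccc(F)cc3)nn2)cc1` differs from compound 2 by fluoro in place of methyl on an aromatic carbon. Going by the values given here, the only measured step, moving a methyl between positions, does not involve a fluoro and therefore says nothing direct about this change; with no guide, the expected step is none beyond the scatter a 1.0-fold higher number from compound 2 to compound 3 (0.00 log units; within the scatter). Compound 3 is estimated to give 4000 nM, in a range from 1500 nM to 12000 nM.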

Compound 3, half-maximal inhibitory concentration: 20000 nM
For compound 3 the middle estimate is 5.0-fold (0.70 log units) below the measured one; the measured number lies above the stated range.
By their numbers in this assay, from the lowest: compounds 2 and 1 (each within the scatter of the next); then compound 3.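

Changing 4-methylphenyl to 4-fluorophenyl gives a 5.0-fold higher number from compound 2 to compound 3 (0.70 log units; beyond the scatter) in this assay, so the group at this place on the outer ring can shift the number beyond the scatter, which moving the methyl did not do. The change from 3-methylphenyl to 4-fluorophenyl points the same way, with a 2.7-fold higher number from compound 1 to compound 3 (0.44 log units; beyond the scatter). Nothing available here explains why the fluoro compound is the weaker inhibitor.

As far as these compounds go, whether a methoxy, a chloro or an amine at this place would behave like methyl or like fluoro remains open.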